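A chlorine relocated on the way to compound 3

This account rests on a few compounds, and the source may have more. Where it says the series, first, only, none or still open, it means among the compounds named here.

The two measured compounds share one core and differ only in the substituted ring hung on a saturated chain carbon bound to an oxygen on an aromatic ring. Compound 1 `O=C(Nc1cccnc1)c1ccccc1OCc1c(F)cccc1Cl` carries a 2-chloro-6-fluorophenyl group there; in an assay on lysate for inhibition of phosphatidylcholine:ceramide cholinephosphotransferase 2 (Homo sapiens), read by HPLC, with stated times of 30 min and 2 h (on this read-out lower numbers stand for stronger inhibition and higher numbers for weaker inhibition), compound 1 gives 1500 nM. Compound 2 `Cc1ccc(Cl)cc1COc1ccccc1C(=O)Nc1cccnc1` carries 5-chloro-2-methylphenyl at that place, and in this assay compound 2 gives 1100 nM. Going by the values given here, the single measured step, a 1.4-fold lower number from compound 1 to compound 2 (0.13 log units; within the scatter), lies within the scatter, so compound 2 stands at the lower of the two numbers without being set apart from compound 1.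

Compound 3 `Cc1c(Cl)cccc1COc1ccccc1C(=O)Nc1cccnc1` differs from compound 2 by 3-chloro-2-methylphenyl in place of 5-chloro-2-methylphenyl on a saturated chain carbon bound to an oxygen on an aromatic ring. Among the compounds with values here, only the step from compound 1 to compound 2 bears on this change: it also reshuffled the substituents on that same ring, and the number did not move beyond the scatter. On that evidence no step beyond the scatter is expected in this assay, in either direction. The expected step is no change at the digits printed from compound 2 to compound 3 (within the scatter). Compound 3 is estimated to give 1100 nM in this assay, with a range from 400 nM to 3000 nM.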

Compound 3, half-maximal inhibitory concentration: 3800 nM
Compound 3: middle estimate off by 3.5-fold (0.54 log units), on the low side; measured number above the stated range.
By their numbers in this assay, from the lowest: compounds 2 and 1 (each within the scatter of the next); then compound 3.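

In this assay, 3-chloro-2-methylphenyl in place of 5-chloro-2-methylphenyl on a saturated chain carbon bound to an oxygen on an aromatic ring gives a 3.5-fold higher number from compound 2 to compound 3 (0.54 log units; beyond the scatter). This place therefore responds to how the same atoms are arranged on the ring, a sensitivity that the earlier step within the scatter had not revealed. The 3-chloro-2-methylphenyl group also separates from the 2-chloro-6-fluorophenyl group, with a 2.5-fold higher number from compound 1 to compound 3 (0.40 log units; beyond the scatter), which leaves compound 3 as the weakest of the three in this assay, though nothing available here accounts for the difference.

With only three substituted rings at this place, the compounds shown leave open whether the shift follows the chlorine alone or depends on the methyl group that accompanies it in compound 2 and compound 3. They also do not show how an unsubstituted phenyl group would compare, or what a trifluoromethyl group or a nitrile would do in place of the chlorine.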